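Chloro for hydrogen on the fused core of compound 1

A few compounds are considered here, and "the series" means these few. Any claim that something is new, unique, unknown or untested is made for them only; others in the source may bear on it.

Among the measured compounds shown here, compound 1 `ClCc1ccccc1Cn1cnc2ncnc(Cl)c21` stands highest of the three numbers so far in a functional assay on OVCAR-4 cells (Homo sapiens) for cytotoxicity, read by sulforhodamine B assay, with a stated time of 48 h; a lower number here means that less compound is tolerated, a higher number that more compound is tolerated: compound 1 gives 77600 nM. In this assay compound 3 `Nc1nc(Cl)c2ncn(Cc3cccc(CCl)c3)c2n1` gives 9540 nM. Set against compound 1, that is a lower number, with the gap beyond the scatter. Compound 2 `ClCc1cccc(Cn2cnc3nc(Cl)nc(Cl)c32)c1` gives 5370 nM, the lowest of the three; both differ from compound 1 in more than one place, so no single step can be read from them. Compound 4 `ClCc1ccccc1Cn1cnc2nc(Cl)nc(Cl)c21` differs from compound 1 by chloro in place of hydrogen on an aromatic carbon, between two ring nitrogen atoms. Because compound 2, which also carries two chloro groups on its core, gives 5370 nM, a drop in the number is expected for compound 4, estimated as a 3.9-fold lower number from compound 1 to compound 4 (0.59 log units; beyond the scatter). Compound 4 is estimated at 20000 nM, within 5000 nM to 80000 nM.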

Compound 4, concentration lethal to 50% of the cells: > 100000 nM
Compound 4: no number, only a limit; the forecaster's own chance of this, stated with the estimate: 5%; at least 5.0-fold (0.69 log units) between middle value and limit.
By their numbers in this assay, from the lowest: compounds 2 and 3 (each within the scatter of the next); then compound 1. At a limit, above all of these: compound 4.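

Compound 4 gives > 100000 nM in this assay, and that value is a limit of the assay, not a number. Chloro on the aromatic carbon between two ring nitrogen atoms gives an at least 1.2-fold higher number from compound 1 to compound 4 (0.11 log units; that floor lies within the scatter), so no drop appears at this position on the core of compound 1, though that floor alone does not separate the two compounds. The reading is bounded by the assay's ceiling: the limit of > 100000 nM in this assay, at which 1 of the 4 values shown sits.

As far as these compounds go, the true value of compound 4 remains open. Also open, from the compounds shown here alone, is whether a methyl or methoxy group at this position would move the number as chloro does.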